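The compounds below may be only part of what the source reports. "The series", "measured", "known", "first", "only" and "open" are said of these compounds alone.

Measured so far:
compound 1 `C=C1CCCC(C)(C)C1CC[C@]1(C)CC[C@@H]([C@@H](C)C(=O)O)OO1`: > 5000 nM
compound 2 `C=C1CCC[C@@H]2[C@@H](CC[C@@]3(C)CC[C@H]([C@H](C)C(=O)O)OO3)[C@H](C)CC[C@@]12C`: 960 nM
compound 3 `C=C1CCCC(C)(C)C1CC[C@]1(C)CC[C@H]([C@@H](C)C(=O)OC)OO1`: 4950 nM

All three were tested in a functional assay on BT-549 cells (Homo sapiens) for cytotoxicity, read by colony formation; on this read-out higher numbers stand for weaker inhibition of growth and lower numbers for stronger inhibition of growth. For compound 1 the assay returns only a limit, > 5000 nM, and no number. Compound 2 gives 960 nM. Compound 3 gives 4950 nM. Within the data shown here, compound 1 therefore stands at the weak end of what has been measured, the single compound resting at the limit: the limit of > 5000 nM in this assay, at which 1 of the 3 values shown sits.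

Compound 4 `C=C1CCCC(C)(C)C1CC[C@@]1(C)CC[C@H]([C@@H](C)C(=O)O)OO1` has not yet been measured. It differs from compound 1 only in its stereochemistry: the two compounds have the same atoms and bonds; at least one stereo element is drawn with a configuration in one of them and without one in the other: 2 of 4 stereo elements differ; a stereocentre at a saturated ring carbon is drawn R in compound 1 and S in compound 4; a stereocentre at a saturated ring carbon is drawn S in compound 1 and R in compound 4. Among the measured compounds shown here, no step between two measured compounds is available to gauge a change of this kind. Compound 1 sits at the limit and offers no number to move from. Compound 3, sharing the same core, gives 4950 nM, which also lies in the weak region. The step of a number no higher from compound 1 to compound 4 (the limit leaves the size open) is expected to be none beyond the scatter. Compound 4 is estimated at 5000 nM, with a range from 2000 nM to 20000 nM, and it may well be reported again only as a limit.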

Compound 4, concentration for 50% growth inhibition: 1050 nM
Estimate against measurement, compound 4: 4.8-fold (0.68 log units) above, and the stated range ends above it.
By their numbers in this assay, from the lowest: compounds 2 and 4 (each within the scatter of the next); then compound 3. At a limit, above all of these: compound 1.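

In this assay, exchanging the drawn configuration at two saturated ring carbons, with atoms and bonds unchanged, gives an at least 4.7-fold lower number from compound 1 to compound 4 (0.67 log units; beyond the scatter). Among these compounds, this is the first comparison to gauge a purely stereochemical change, and it shows that stereochemistry alone can move the number beyond the scatter on this core. Compound 1 stands at a limit, so the step has a minimum but no known size: the limit of > 5000 nM in this assay, at which 1 of the 4 values shown sits.

On these data alone, how much each of the two stereocentres contributes on its own remains open, and the comparison carries a further qualification: the fact that one of compounds 1 and 4 is drawn with a defined configuration and the other without, at the place where they differ. As far as these compounds go, it is also open whether the lower number of compound 4 would persist if a primary amide or a hydroxymethyl group stood in place of its carboxylic acid.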